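This account rests on a few compounds, and the source may have more. Where it says the series, first, only, none or still open, it means among the compounds named here.

Compound 2, `CCN(CC)S(=O)(=O)c1ccc(S(=O)(=O)N2CCC[C@@H](C(=O)N3CCS(=O)(=O)CC3)C2)cc1`, gives 4430 nM in a functional assay on BXPC-3 cells (Homo sapiens) for inhibition, read by MTT assay, with a stated time of 7 days (on this read-out higher numbers stand for weaker inhibition and lower numbers for stronger inhibition), the higher of the two numbers recorded so far. Among the compounds with values here, its only neighbour is compound 1, `CCN(CC)S(=O)(=O)c1ccc(S(=O)(=O)N2CCC[C@@H](C(=O)N3CCC(COC)CC3)C2)cc1`, which in this assay gives 1360 nM, and the step between them is a 3.3-fold higher number from compound 1 to compound 2 (0.51 log units; beyond the scatter). Compound 3, `CCN(CC)S(=O)(=O)c1ccc(S(=O)(=O)N2CCC[C@@H](C(=O)N3CC[C@@H](OC)C3)C2)cc1`, is not yet measured. It differs from compound 2 in one place: 3-methoxypyrrolidin-1-yl in place of 1,1-dioxothiomorpholin-4-yl on a carbonyl carbon. Within the data shown here, the single measured step bears on this change only indirectly, since it shows what the exchange of a methoxy-bearing ring for the sulfone ring did between compound 1 and compound 2; compound 3 brings a methoxy-bearing ring back, though a five-membered one. On that basis compound 3 is expected to come in with a lower number than compound 2, with the step estimated as a 2.2-fold lower number from compound 2 to compound 3 (0.35 log units; beyond the scatter). The value for compound 3 in this assay is therefore estimated at 2000 nM, within a range from 800 nM to 5000 nM.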

Compound 3, half-maximal inhibitory concentration: 11500 nM
Estimate against measurement, compound 3: 5.8-fold (0.76 log units) below, and the stated range ends below it.
By their numbers in this assay, from the lowest: compound 1; then compound 2; then compound 3.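

Across the three compounds in this assay, a methoxy-bearing group on this carbonyl carbon does not by itself give a lower number: 3-methoxypyrrolidin-1-yl in place of 1,1-dioxothiomorpholin-4-yl gives the opposite direction (a 2.6-fold higher number from compound 2 to compound 3 (0.41 log units; beyond the scatter)). The two methoxy-bearing groups also lie far apart, with 3-methoxypyrrolidin-1-yl in place of 4-(methoxymethyl)piperidin-1-yl giving the largest of the steps shown (an 8.5-fold higher number from compound 1 to compound 3 (0.93 log units; beyond the scatter)), so this position separates them clearly. Nothing available explains these differences.

Compound 1 and compound 3 differ in both ring size and the methoxy-bearing side group, so the compounds shown cannot separate those two features; a 3-methoxypiperidin-1-yl group or a 3-(methoxymethyl)pyrrolidin-1-yl group would bear on that. Also open, as far as these compounds go, is how the opposite stereocentre in 3-methoxypyrrolidin-1-yl, or an unsubstituted pyrrolidin-1-yl, would read here.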